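This account rests on a few compounds, and the source may have more. Where it says the series, first, only, none or still open, it means among the compounds named here.

Compound 1 `CCOC(=O)c1c(C)nc(-c2cccc(C#N)c2)n1OCc1ccncc1`: 6200 nM
Compound 2 `CCOC(=O)c1c(C)nc(-c2cccc(C#N)c2)n1OCc1ccccc1`: 5930 nM

In a functional assay on a cell-free system (plasma, Oryctolagus cuniculus) for inhibition, with stated times of 5 min, 1 min and 6 min (on this read-out lower numbers stand for stronger inhibition and higher numbers for weaker inhibition), compound 2 gives 5930 nM, within the scatter of compound 1 at 6200 nM. Compound 3 `CCOC(=O)c1c(C)nc(-c2cccc(C#N)c2)n1OCc1ccccc1F` differs from compound 2 in one place: fluoro in place of hydrogen on an aromatic carbon, which turns benzyloxy into (2-fluorobenzyl)oxy. Among the compounds with values here, the one measured step, a 1.0-fold lower number from compound 1 to compound 2 (0.02 log units; within the scatter), put phenyl in place of pyridin-4-yl and bears on this change only indirectly. Within the data shown here, no measured step involves a fluoro, so no step beyond the scatter is expected in this assay. The estimated step is a 1.1-fold lower number from compound 2 to compound 3 (0.03 log units; within the scatter). Compound 3 is expected at 5500 nM, with an estimated range of 2500 nM to 12000 nM.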

Compound 3, half-maximal inhibitory concentration: 8990 nM
Beside the measured number, compound 3's estimate is 1.6-fold (0.21 log units) below it; the range from low to high includes it.
By their numbers in this assay, from the lowest: compounds 2, 1 and 3 (each within the scatter of the next).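

In this assay, fluoro in place of hydrogen on an aromatic carbon, ortho to a large group, gives a 1.5-fold higher number from compound 2 to compound 3 (0.18 log units; within the scatter) and so shows no change beyond the scatter. Measured against the pyridin-4-yl compound, 2-fluorophenyl gives a 1.5-fold higher number from compound 1 to compound 3 (0.16 log units; within the scatter), which also stays within the scatter, so all three aromatic end groups read alike here. Nothing on hand explains these numbers.

The compounds shown leave open whether a larger group on this ring, such as methoxy or an amine, would move the number beyond the scatter. They also leave open how a carboxylic acid in place of the ethyl ester would read.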